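The compounds below may be only part of what the source reports. "The series", "measured", "known", "first", "only" and "open" are said of these compounds alone.

Measured so far in an ADME assay on BHK cells (Mesocricetus auratus) for cytotoxicity, read by MTT assay, with a stated time of 96 h; on this read-out higher numbers stand for lower toxicity in this test and lower numbers for higher toxicity in this test:
Compound 1, `CCC(=O)Nc1ccc(-c2nc3cc(C(F)(F)F)ccc3[nH]2)cc1`, gives 100000 nM.
Compound 2, `CC(=O)Nc1ccc(-c2nc3ccccc3[nH]2)cc1`, gives only a limit, > 100000 nM.

Compound 2 thus stands at the edge of this assay rather than on a number; (the limit of > 100000 nM in this assay, at which 1 of the 2 values shown sits). Only a bound is known for it, no position on the scale.

Compound 3, `CCC(=O)Nc1ccc(-c2nc3ccccc3[nH]2)cc1`, differs from compound 2 by methyl in place of hydrogen on a saturated chain carbon bound to a carbonyl carbon. For the measured compounds named here, no measured pair carries this change, so no measured step is available for it. Compound 1 carries the same propanoylamino group together with a trifluoromethyl on its core and lies at a high concentration in this assay. Given that, the step from compound 2 to compound 3 is expected to stay within the scatter in this assay, a number no higher from compound 2 to compound 3 (the limit leaves the size open). Compound 3 is expected near 100000 nM, in the range 50000 nM to 200000 nM, with a real chance that this assay again returns only a limit.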

Compound 3, half-maximal cytotoxic concentration: >= 100000 nM
Compound 3 ended at the assay's limit (the forecaster's own chance of this, stated with the estimate: 55%); the middle value sits exactly at the limit.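

In this assay, the propanoylamino group now appears on the shared core without the trifluoromethyl of compound 1, and methyl in place of hydrogen on a saturated chain carbon bound to a carbonyl carbon leaves the read-out at the edge of the assay. Compound 3 carries a limit, not a number: the limit of >= 100000 nM in this assay, at which 1 of the 3 values shown sits.

Hydrogen in place of trifluoromethyl on an aromatic carbon gives a number no lower from compound 1 to compound 3 (the limit leaves the size open), while the step for the methyl change cannot be read, with limits at both ends.

Still open, from the compounds shown here alone, is whether any change at this chain brings the shared core onto the scale, for example a longer chain such as butanoyl, or an amine or a carboxylic acid at its end. Also open, going by these compounds, is whether trifluoromethyl on the core, paired with the acetamido group of compound 2, would read like compound 1.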